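An Ether in Place of the Amide at the Ring Carbon

The source may report more compounds than this note shows. Statements on the series, on what has been measured and on what is new or still open speak of the compounds shown alone.

Two measured compounds share one core and differ only in the group on a saturated ring carbon. Compound 1 `COc1ccc(CCOC2CC(=O)Nc3c2c(C)nn3-c2ncnc3nc[nH]c23)cc1` carries an ether-linked side chain there; in a functional assay on HEK293 cells for agonist activity at G-protein coupled receptor 39 (Homo sapiens), read by scintillation proximity assay and inositol phosphate accumulation, with a stated time of 75 min, in the presence of a further agent that is not named here (a higher number here means that more compound is needed for the effect, a lower number that less compound is needed), compound 1 gives 2 nM. Compound 2 `Cc1nn(-c2ncnc3nc[nH]c23)c2c1C(NC(=O)c1ccccc1)CC(=O)N2` carries a benzamido group at the same carbon; in this assay compound 2 gives 3 nM, the larger of the two numbers, though its gap to compound 1 lies within the scatter, so neither compound can be called the more potent. Compound 3 `Cc1nn(-c2ncnc3nc[nH]c23)c2c1C(OCc1ccc(C#N)cc1)CC(=O)N2` has not been measured. It differs from compound 2 in one place: (4-cyanobenzyl)oxy in place of benzamido on a saturated ring carbon. Since both an amide link and an ether link at this carbon have given low numbers, only a small step is expected, and the step of a 1.7-fold higher number from compound 2 to compound 3 (0.22 log units; within the scatter) is estimated to stay close to the scatter, if anything slightly upward. For compound 3 a value of 5 nM is expected, within 1.5 nM to 20 nM.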

Compound 3, half-maximal effective concentration: 4 nM
Compound 3: middle estimate off by 1.3-fold (0.10 log units), on the high side; low and high end bracket the measured number.
By their numbers in this assay, from the lowest: compounds 1, 2 and 3 (each within the scatter of the next).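

The change from benzamido to (4-cyanobenzyl)oxy on the saturated ring carbon gives, in this assay, a 1.3-fold higher number from compound 2 to compound 3 (0.12 log units; within the scatter), so a second ether at this carbon keeps the number in the same low range even though the hydrogen-bond donor of benzamido is gone and a nitrile has entered. The two ethers also stay together, with 4-cyanophenyl in place of 4-methoxybenzyl on the chain giving a 2.0-fold higher number from compound 1 to compound 3 (0.30 log units; within the scatter), so this change of ether side chain does not separate them either. Nothing measured here explains why these changes leave the number within the scatter.

All three groups at this carbon carry a six-membered aromatic ring of carbon only. As far as these compounds go, whether an amine, a carboxylic acid or a plain hydroxyl there would keep the number this low remains open.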